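Cytotoxicity notes on a benzylimidazole aniline series

This account rests on a few compounds, and the source may have more. Where it says the series, first, only, none or still open, it means among the compounds named here.

Measured so far in a toxicity assay on NIH3T3 cells (Mus musculus) for cytotoxicity, read by resazurin assay; on this read-out higher numbers stand for an effect only at larger amounts of compound and lower numbers for an effect already at smaller amounts:
compound 1, `COC(=O)c1ccc(NCc2cncn2Cc2ccccc2C(C)(C)C)cc1-c1ccccc1`, "not determined" (no result reported)
compound 2, `COC(=O)c1ccc(NCc2cncn2Cc2ccc(Br)cc2)cc1-c1ccccc1`, > 10000 nM
compound 3, `COC(=O)c1ccc(NCc2cncn2Cc2cccc(-c3ccccc3)c2)cc1-c1ccccc1`, "not determined" (no result reported)

Of the three compounds shown, only compound 2 carries an entry in this assay, and that entry is a limit of the assay rather than a number. The other two entries, for compound 1 and compound 3, give no value at all. Compound 3 therefore stands without a number of its own; beside it, one further value in the series is a limit and one further entry has no number. The single fixed point is the limit of > 10000 nM in this assay, at which 1 of the 3 values shown sits.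

The unmeasured compound is compound 4, `COC(=O)c1ccc(NCc2cncn2Cc2ccccc2Br)cc1-c1ccccc1`. It differs from compound 3 in one place: 2-bromophenyl in place of 3-phenylphenyl on a saturated chain carbon bound to an aromatic nitrogen. Among the compounds with values here, since no step between measured compounds is available in this assay, nothing can be said about the size or direction of a change from compound 3 to compound 4; the expectation is for no step beyond the scatter. Within the data shown here, the only anchor is compound 2, whose bromophenyl analogue sits at the limit, so compound 4 is expected to show no cytotoxic effect within the tested range as well. For compound 4 the estimate in this assay is 15000 nM, with a range from 5000 nM to 50000 nM, most likely reported as a limit.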

Compound 4, half-maximal effective concentration: 10000 nM
Compound 4: middle estimate off by 1.5-fold (0.18 log units), on the high side; the measured number falls inside the stated range.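

Working notes on the bromine position: in this assay, 2-bromophenyl in place of 4-bromophenyl on a saturated chain carbon bound to an aromatic nitrogen gives a number no higher from compound 2 to compound 4 (the limit leaves the size open). Compound 4, at 10000 nM, is the first compound shown to carry a single number rather than a limit or an empty entry, so this position now has one fixed value in this assay. The entry for compound 2 remains a limit of the assay, so the pair gives a direction that allows no change at all as well as a larger one, and its only anchor is this: the limit of > 10000 nM in this assay, at which 1 of the 4 values shown sits.

The pair therefore leaves open how large the step between the two bromophenyl groups is, and the entry for compound 3 holds no number, so the exchange of 3-phenylphenyl for 2-bromophenyl has no readable size either. The compounds shown also leave open what a carboxylic acid or an amine on this same phenyl group, in place of the bromine, would give in this assay.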